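The source may hold more compounds than are shown below. What is called first, only, known or untested is meant among the compounds shown, and "the series" means these compounds.

Measured compounds in a functional assay on A549 cells (Homo sapiens) for antiproliferative activity, read by MTT assay, with a stated time of 48 h; on this read-out lower numbers stand for stronger inhibition and higher numbers for weaker inhibition:
- Compound 1 `CCc1ccccc1-n1nncc1CN1C(=O)C2(C(C#N)=C(N)Oc3c(N)cc4nc5ccccc5nc4c32)c2ccccc21` gives 24600 nM.
- Compound 2 `N#CC1=C(N)Oc2c(N)cc3nc4ccccc4nc3c2C12C(=O)N(Cc1cnnn1-c1ccc(Cl)cc1)c1ccccc12` gives > 50000 nM, which is a limit of the assay and not a number.
- Compound 3 `N#CC1=C(N)Oc2c(N)cc3nc4ccccc4nc3c2C12C(=O)N(Cc1cnnn1-c1ccccc1Cl)c1ccccc12` gives 29800 nM.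

Compound 3 and compound 1 sit within the scatter of one another in this assay, as the step of a 1.2-fold higher number from compound 1 to compound 3 (0.08 log units; within the scatter) shows; the third value in the set is a limit (the limit of > 50000 nM in this assay, at which 1 of the 3 values shown sits).

Compound 4 `N#CC1=C(N)Oc2c(N)cc3nc4ccccc4nc3c2C12C(=O)N(Cc1cnnn1-c1cccc(Br)c1)c1ccccc12` is not yet measured. It differs from compound 3 by 3-bromophenyl in place of 2-chlorophenyl on an aromatic nitrogen. For the measured compounds named here, two measured steps bear on exchanges of the aryl group on the triazole nitrogen: an at least 2.0-fold higher number from compound 1 to compound 2 (0.30 log units; that floor lies within the scatter) and an at least 1.6-fold lower number from compound 2 to compound 3 (0.22 log units; that floor lies within the scatter). Both have a floor within the scatter, and the step of a 1.2-fold higher number from compound 1 to compound 3 (0.08 log units; within the scatter) is also within the scatter. On these data a change of the aryl substituent gives no step beyond the scatter in this assay, so for compound 4 a step of about a 1.2-fold higher number from compound 3 to compound 4 (0.07 log units; within the scatter) is expected, with no clear direction. Compound 4 is therefore estimated at 35000 nM in this assay, between 15000 nM and 80000 nM.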

Compound 4, half-maximal inhibitory concentration: 18900 nM
Compound 4: the middle estimate sits 1.9-fold (0.27 log units) above what was measured; the measured number falls inside the stated range.
By their numbers in this assay, from the lowest: compounds 4, 1 and 3 (each within the scatter of the next). At a limit, above all of these: compound 2.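

In this assay, the exchange on the aromatic nitrogen gives the only step in the series shown that lies beyond the scatter: an at least 2.6-fold lower number from compound 2 to compound 4 (0.42 log units; beyond the scatter). That step rests on compound 2, whose reading is a limit and not a number: the limit of > 50000 nM in this assay, at which 1 of the 4 values shown sits. The steps of a 1.6-fold lower number from compound 3 to compound 4 (0.20 log units; within the scatter) and a 1.3-fold lower number from compound 1 to compound 4 (0.11 log units; within the scatter) stay within the scatter, so the 3-bromophenyl is set apart from the 4-chlorophenyl only, not from the 2-chlorophenyl or the 2-ethylphenyl.

On these data alone, compound 2 and compound 4 differ in both the halogen and its place on the phenyl ring, and which of the two carries the step stays open. A 3-chlorophenyl or a 4-bromophenyl would separate them, and the effect of an unsubstituted phenyl or an aminophenyl at this position is also unknown.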